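Phenoxy for phenylsulfanyl: a note on compound 3

The compounds below may be only part of what the source reports. "The series", "measured", "known", "first", "only" and "open" are said of these compounds alone.

Measured so far:
compound 1 `COc1cc(OCc2cccc(COc3ccccc3)c2)c2cc(-c3cn4nc(OC)sc4n3)oc2c1` — 600 nM
compound 2 `COc1cc(OCc2cccc(Sc3ccccc3)c2)c2cc(-c3cn4nc(OC)sc4n3)oc2c1` — 410 nM

In an assay on a cell-free system (plasma) for antagonist activity at proteinase-activated receptor 4 (Homo sapiens), with a stated time of 5 min, in the presence of a further agent that is not named here (a lower number here means a stronger inhibitor, a higher number a weaker inhibitor), compound 1 gives 600 nM and compound 2 gives 410 nM. Among the compounds with values here, the lower of the two numbers belongs to compound 2, but the only step measured, a 1.5-fold lower number from compound 1 to compound 2 (0.17 log units; within the scatter), lies within the scatter, so neither compound can be called the stronger. Compound 3 `COc1cc(OCc2cccc(Oc3ccccc3)c2)c2cc(-c3cn4nc(OC)sc4n3)oc2c1` differs from compound 2 by phenoxy in place of phenylsulfanyl on an aromatic carbon. Within the data shown here, no measured step exchanges these two groups directly; the one step known was within the scatter, so no movement beyond the scatter is expected: a 1.2-fold higher number from compound 2 to compound 3 (0.09 log units; within the scatter). Compound 3 is therefore estimated at 500 nM, with a range from 200 nM to 1300 nM.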

Compound 3, half-maximal inhibitory concentration: 390 nM
For compound 3 the middle estimate is 1.3-fold (0.11 log units) above the measured one; measured number inside the range.
By their numbers in this assay, from the lowest: compounds 3, 2 and 1 (each within the scatter of the next).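

Phenoxy in place of phenylsulfanyl on this aromatic carbon, meta to a large group, gives a 1.1-fold lower number from compound 2 to compound 3 (0.02 log units; within the scatter), and phenoxy in place of phenoxymethyl gives a 1.5-fold lower number from compound 1 to compound 3 (0.19 log units; within the scatter). All three groups at this position therefore read alike within the scatter, including the direct exchange of sulfur for oxygen in the link to the phenyl ring. No available evidence bears on why these groups read alike. Still open, as far as these compounds go, is whether an amine, a carboxylic acid or a longer chain ending in phenyl at this carbon would move the number beyond the scatter.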